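The compounds below may be only part of what the source reports. "The series", "measured", "known", "first", "only" and "open" are said of these compounds alone.

Compound 1 `COc1ccc2c(c1)NC(=O)CN2c1nc(NCCCO)nc2ccccc12` gives 5.18 nM in a functional assay on A549 cells (Homo sapiens) for inhibition, read by sulforhodamine B assay, with a stated time of 48 h (on this read-out lower numbers stand for stronger inhibition of growth and higher numbers for weaker inhibition of growth), the lowest of the three numbers measured. Compound 2 `COc1ccc2c(c1)NC(=O)CN2c1nc(Nc2cccc(C#N)c2)nc2ccccc12` gives 75.4 nM, and compound 3 `COc1ccc2c(c1)NC(=O)CN2c1nc(N2CC(OC)C2)nc2ccccc12` gives 17.5 nM. Both changes made at the same position move away from compound 1: a 15-fold higher number from compound 1 to compound 2 (1.16 log units; beyond the scatter), and a 3.4-fold higher number from compound 1 to compound 3 (0.53 log units; beyond the scatter). Between the other two, a 4.3-fold lower number from compound 2 to compound 3 (0.63 log units; beyond the scatter).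

Compound 4 `COc1ccc2c(c1)NC(=O)CN2c1nc(NC2CCCC2)nc2ccccc12` has not been measured in this assay. It differs from compound 1 in one place: cyclopentyl in place of 3-hydroxypropyl on a nitrogen on an aromatic ring. The group that enters is a five-membered non-aromatic ring of carbon only with no hydrogen-bond donor or acceptor, whereas the 3-hydroxypropyl that leaves carries one of each. The two measured steps away from compound 1 both gave higher numbers, modest for 3-methoxyazetidin-1-yl and large for 3-cyanophenyl; cyclopentyl resembles neither closely, so a step of intermediate size toward a higher number is expected, with the result still uncertain. Compound 4 is expected at 20 nM, within 6 nM to 70 nM, which would mean an expected step of a 3.9-fold higher number from compound 1 to compound 4 (0.59 log units; beyond the scatter).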

Compound 4, concentration for 50% growth inhibition in the A549 assay: 7.67 nM
Estimate against measurement, compound 4: 2.6-fold (0.42 log units) above; the range from low to high includes it.
By their numbers in the A549 assay, from the lowest: compounds 1 and 4 (each within the scatter of the next); then compound 3; then compound 2.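

In the A549 assay the hydrogen-bond donor and acceptor of 3-hydroxypropyl are not needed on this nitrogen: cyclopentyl carries neither, yet the result is a 1.5-fold higher number from compound 1 to compound 4 (0.17 log units; within the scatter) for this change. The place still separates groups, with a 2.3-fold lower number from compound 3 to compound 4 (0.36 log units; beyond the scatter) and a 9.8-fold lower number from compound 2 to compound 4 (0.99 log units; beyond the scatter) on the same read-out, so the higher numbers of compound 2 and compound 3 do not follow from the loss of 3-hydroxypropyl as such. In a physicochemical assay for lipophilicity, read by HPLC, measured as octanol-water partition, tested at 1 mg/mL (on this read-out higher numbers stand for higher lipophilicity and lower numbers for lower lipophilicity), compound 1 gives 2.6 and compound 4 gives 2.33 on the partition scale, which is a number 0.27 log units lower from compound 1 to compound 4 (within the scatter) for the same change.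

Nothing shown gives a reason for these results. Open, as far as these compounds go, is how a longer chain ending in a hydroxyl, a carboxylic acid or a cyclohexyl ring on this nitrogen would read in the A549 assay against cyclopentyl and 3-hydroxypropyl.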